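A Phenyl in Place of Methoxy on the Nitrogen

The source may hold more compounds than are shown below. What is called first, only, known or untested is meant among the compounds shown, and "the series" means these compounds.

Three compounds have so far been measured in a functional assay for inhibition of serine protease 1 (Homo sapiens), tested at 0.1 mM; on this read-out higher numbers stand for a stronger effect at the one concentration tested and lower numbers for a weaker effect:

compound 1, `O=c1ccc2ccc(/C=N/Nc3ccccc3)cc2o1`, 31.4%
compound 2, `CO/N=C/c1ccc2ccc(=O)oc2c1`, 25.5%
compound 3, `O=c1ccc2ccc(/C=N/N=C/c3ccc4ccc(=O)oc4c3)cc2o1`, 9.4%

Among these three numbers compound 2 stands second. Compound 1 lies nearest to it, with a value a few points higher that remains within the usual scatter, so the two cannot be told apart on this read-out. Compound 3 lies furthest away, with a value that falls below compound 2 by more than the scatter.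

The next compound, compound 4, `O=c1ccc2ccc(/C=N/c3ccccc3)cc2o1`, has not yet been measured. It differs from compound 2 in one place: phenyl in place of methoxy on a double-bonded nitrogen. Within the data shown here, no directly comparable step between measured compounds exists for this change, so its effect in this assay can only be guessed. The measured values give no reason to expect a step beyond the scatter; compound 1, which also carries a phenyl-bearing nitrogen, gives 31.4%, which is within the scatter of compound 2.

On this basis compound 4 is expected to give about 28%, in a range from 12% to 45%, which means an expected step of a number 2.5 percentage points higher from compound 2 to compound 4 (within the scatter).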

Compound 4, a percentage reported as inhibition, at one concentration (the size of the read-out at that concentration, not a potency): 22.6%
For compound 4 the middle estimate is 5.4 percentage points above the measured one, and the stated range covers the measured number.
By their numbers in this assay, from the lowest: compound 3; then compounds 4, 2 and 1 (each within the scatter of the next).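

Phenyl in place of methoxy on a double-bonded nitrogen now has a direct reading in this assay, and the change amounts to a number 2.9 percentage points lower from compound 2 to compound 4 (within the scatter). Among these compounds, this is the first measured pair of compounds that differ in one place, and it shows that a group of 6 heavy atoms with one six-membered aromatic ring of carbon only can stand where methoxy, with 2 heavy atoms and 1 hydrogen-bond acceptor, stood, with no difference that can be told from the usual scatter on this read-out. No measurement at hand bears on why compound 2 and compound 4 read alike.

The compounds shown leave open whether any group on this nitrogen would move the read-out beyond the scatter from compound 2, for instance a longer chain such as butoxy, or a phenyl carrying a carboxylic acid or an amine. They also leave open whether the absence of a clear step between methoxy and phenyl would hold on a different core, since this change is read here in a single pair.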